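A few compounds are considered here, and "the series" means these few. Any claim that something is new, unique, unknown or untested is made for them only; others in the source may bear on it.

In a functional assay on MCF7 cells (Homo sapiens) for inhibition, read by MTT assay, with a stated time of 48 h (a lower number here means a stronger inhibitor, a higher number a weaker inhibitor), compound 1 `COc1cc2cc(NC(C)=O)c(=O)oc2cc1OCCCOc1no[n+]([O-])c1S(=O)(=O)c1ccccc1` gives 2400 nM. Compound 3 `COc1cc2cc(N)c(=O)oc2cc1OCCCOc1no[n+]([O-])c1S(=O)(=O)c1ccccc1` differs from it by hydrogen in place of acetyl on a nitrogen on an aromatic ring, and in this assay compound 3 gives 1910 nM, so that the change made a 1.3-fold lower number from compound 1 to compound 3 (0.10 log units; within the scatter). Compound 2 `COc1cc2cc(NC(C)=O)c(=O)oc2cc1OCCCCOc1no[n+]([O-])c1S(=O)(=O)c1ccccc1` carries a different core, and the difference between the two cores is not broken down here; in this assay compound 2 gives 3440 nM, and all three measured numbers sit within the scatter of one another. Compound 4 `COc1cc2cc(N)c(=O)oc2cc1OCCCCOc1no[n+]([O-])c1S(=O)(=O)c1ccccc1` stands to compound 2 as compound 3 stands to compound 1, namely (hydrogen in place of acetyl on a nitrogen on an aromatic ring), at the same place. Because the earlier step of a 1.3-fold lower number from compound 1 to compound 3 (0.10 log units; within the scatter) stayed within the scatter, a step of similar size is expected here: a 1.3-fold lower number from compound 2 to compound 4 (0.11 log units; within the scatter). Compound 4 is therefore estimated at 2700 nM, with a likely range from 1400 nM to 5200 nM.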

Compound 4, half-maximal inhibitory concentration: 2280 nM
The estimate for compound 4 lay 1.2-fold (0.07 log units) above the measured number; measured number inside the range.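

In this assay the change from acetamido to amino gives a 1.5-fold lower number from compound 2 to compound 4 (0.18 log units; within the scatter) and so matches the step on the other core: the same change on two cores in this assay, a 1.3-fold lower number (0.10 log units; within the scatter) from compound 1 to compound 3 and a 1.5-fold lower number (0.18 log units; within the scatter) from compound 2 to compound 4, 1.2-fold (0.08 log units) apart, within the scatter of two such steps. The change therefore carries across these two cores with no difference that can be told apart, and on both it stays within the scatter. This does not show that the change has a real effect on either core, and two cores say nothing about any other core. The compounds shown leave open what other groups on that nitrogen, such as benzoyl or methyl, would give. They also leave open whether the step holds with a longer chain in the linker.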